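From isobutoxy to phenoxy: a step beyond the limit

The source may hold more compounds than are shown below. What is called first, only, known or untested is meant among the compounds shown, and "the series" means these compounds.

Compound 1 `CCOC(=O)c1c(-c2cccc(C)c2)[nH]c2cc(OC)ccc2c1=O`: > 22000 nM (a limit)
Compound 2 `CCOC(=O)c1c(-c2cccc(OC(C)C)c2)[nH]c2cc(OC)ccc2c1=O`: > 22000 nM (a limit)
Compound 3 `CCOC(=O)c1c(-c2cccc(OCC(C)C)c2)[nH]c2cc(OC)ccc2c1=O`: > 22000 nM (a limit)

In an ADME assay on HEK293 cells (Homo sapiens) for cytotoxicity, read by luminescence, with a stated time of 72 h (a higher number here means that more compound is needed for the effect, a lower number that less compound is needed), compound 3 gives > 22000 nM as a limit of the assay and not as a number. The evidence so far is the limit of > 22000 nM in this assay, at which 3 of the 3 values shown sit, and nothing more.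

Compound 4 `CCOC(=O)c1c(-c2cccc(Oc3ccccc3)c2)[nH]c2cc(OC)ccc2c1=O` differs from compound 3 in one place: phenyl in place of isobutyl on an oxygen on an aromatic ring. In words, this is phenyl in place of isobutyl on an oxygen on an aromatic ring, so isobutoxy becomes phenoxy.

Among the compounds with values here, three measured steps bear on this change: a step that the two limits leave unreadable from compound 1 to compound 2, a step that the two limits leave unreadable from compound 1 to compound 3 and a step that the two limits leave unreadable from compound 2 to compound 3. The last is the nearest, since it also swaps the group on that oxygen. None of the three has a readable size, so none offers a size or direction to carry over. Phenyl does bring a ring that none of the three measured compounds carries in this group, which widens the uncertainty. No step beyond the usual scatter is therefore expected in this assay, and no direction can be favoured. The expected outcome is a number no higher from compound 3 to compound 4 (the limit leaves the size open) as an estimate. For compound 4 the estimate is 22000 nM, with an expected range from 10000 nM to 40000 nM and a strong chance of another limit.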

Compound 4, half-maximal effective concentration: > 22000 nM
Compound 4: only a limit was reported; the forecaster's own chance of this, stated with the estimate: 75%; the middle value lies on the limit itself.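

In this assay compound 4 gives > 22000 nM, a limit of the assay and not a number. Within the data shown here, its steps from compound 1, compound 2 and compound 3 cannot be read, so this result yields no new step. The compounds shown leave open how much of each is needed for the effect, and whether changing the group on the oxygen alters that amount at all: the limit of > 22000 nM in this assay, at which 4 of the 4 values shown sit.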